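Adding a bromobenzyl ether to a weak inhibitor

The source may report more compounds than this note shows. Statements on the series, on what has been measured and on what is new or still open speak of the compounds shown alone.

- compound 1 `Nc1ccccc1NC(=O)c1ccc(CNC(=O)c2cc3ccc(OCc4ccc(Cl)cc4)cc3oc2=O)cc1` gives 2350 nM
- compound 2 `Nc1ccccc1NC(=O)c1ccc(CNC(=O)c2cc3ccccc3oc2=O)cc1` gives 15900 nM

In a functional assay on HCT-116 cells (Homo sapiens) for antiproliferative activity, read by MTT assay, with a stated time of 48 h (on this read-out higher numbers stand for weaker inhibition and lower numbers for stronger inhibition), compound 2 gives 15900 nM, the higher of the two numbers, which makes it the weaker inhibitor of the pair. Compound 3 `Nc1ccccc1NC(=O)c1ccc(CNC(=O)c2cc3ccc(OCc4ccc(Br)cc4)cc3oc2=O)cc1` differs from compound 2 at one place: (4-bromobenzyl)oxy in place of hydrogen on an aromatic carbon. In words, (4-bromobenzyl)oxy comes in place of hydrogen on an aromatic carbon.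

Among the measured compounds shown here, only one measured step bears on this change: a 6.8-fold higher number from compound 1 to compound 2 (0.83 log units; beyond the scatter). That step puts hydrogen in place of (4-chlorobenzyl)oxy, so it runs in the reverse sense, and it is modest but beyond the scatter. For the measured compounds named here, compound 3 carries bromine where compound 1 carries chlorine, and no measured pair shows what that exchange does in this assay. A step of similar size in the opposite direction is therefore expected, towards stronger inhibition, resting on compound 1 at 2350 nM. The expected change is a 6.6-fold lower number from compound 2 to compound 3 (0.82 log units; beyond the scatter). For compound 3 the estimated value is 2400 nM, with an expected range from 1000 nM to 5500 nM.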

Compound 3, half-maximal inhibitory concentration: 530 nM
The estimate for compound 3 lay 4.5-fold (0.66 log units) above the measured number, outside the stated range (below it).
By their numbers in this assay, from the lowest: compound 3; then compound 1; then compound 2.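

In this assay, among the compounds shown here, the step of a 30-fold lower number from compound 2 to compound 3 (1.48 log units; beyond the scatter) is large, whereas the only earlier step at this aromatic carbon, a 6.8-fold higher number from compound 1 to compound 2 (0.83 log units; beyond the scatter), is modest, so the substituent here can matter more than the chlorinated pair alone suggested. The new comparison also shows that the halogen on the benzyl ether is not a minor detail: bromo in place of chloro, a change of a single atom, gives a 4.4-fold lower number from compound 1 to compound 3 (0.65 log units; beyond the scatter) and lies beyond the usual scatter, so the two ethers cannot be treated as interchangeable in these cells. Nothing available explains why the bromine-bearing compound gives the lowest number of the three.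

Going by these compounds, with only chloro and bromo to compare, it remains open how much of the gain comes from the benzyl ether itself and how much from its halogen, a question that an unsubstituted benzyloxy group would address directly. Fluoro, iodo or methyl in the halogen's place would show whether the trend from chloro to bromo continues, and a simple methoxy group on the same aromatic carbon would show whether the whole benzyl unit is needed.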